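Ethoxycarbonyl in Place of Thiophen-2-yl: An Expectation

The compounds below may be only part of what the source reports. "The series", "measured", "known", "first", "only" and "open" are said of these compounds alone.

Compound 2 `c1ccc(/N=c2\ssnc2-c2cccs2)cc1` reaches in a functional assay on MDA-MB-231 cells (Homo sapiens) for antiproliferative activity, read by MTT assay, with a stated time of 72 h (on this read-out lower numbers stand for stronger inhibition of growth and higher numbers for weaker inhibition of growth), only a limit, > 10000 nM. Compound 1 `c1ccc(/N=c2\ssnc2-c2ccco2)cc1` likewise gives in this assay only a limit, > 10000 nM. The step that the two limits leave unreadable from compound 1 to compound 2 is thus not readable, as the limit of > 10000 nM in this assay, at which 2 of the 2 values shown sit, shows. Compound 3 `CCOC(=O)c1nss/c1=N\c1ccccc1` differs from compound 2 by ethoxycarbonyl in place of thiophen-2-yl on an aromatic carbon. Among the measured compounds shown here, no measured step bears readably on this change, so no direction or size beyond the scatter can be foreseen. Compound 3 is estimated at 15000 nM, with a range from 3000 nM to 60000 nM. The step that the limit leaves unreadable from compound 2 to compound 3 is expected to remain within unreadable ground.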

Compound 3, concentration for 50% growth inhibition: > 10000 nM
Compound 3 ended at the assay's limit (the forecaster's own chance of this, stated with the estimate: 75%); the middle value lies beyond the limit too.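

Among the compounds shown here, no step among compound 1, compound 2 and compound 3 can be read, because all three end at the same limit: the limit of > 10000 nM in this assay, at which 3 of the 3 values shown sit.

Going by these compounds, whether furan-2-yl, thiophen-2-yl and ethoxycarbonyl differ at all in this assay stays open, as does which group on the shared core would give a readable value.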